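Nitro for hydrogen on the phenyl of compound 3

A few compounds are considered here, and "the series" means these few. Any claim that something is new, unique, unknown or untested is made for them only; others in the source may bear on it.

Three compounds carry a number in an ADME assay on HEL cells (Homo sapiens) for cytotoxicity, with a stated time of 3 days; on this read-out lower numbers stand for higher toxicity in this test and higher numbers for lower toxicity in this test. Compound 1 `Cc1cc(-c2cccc(F)c2)c2ncc(CSCCc3ccccc3)n2c1` gives 35 ug/mL, compound 2 `c1ccc(CCSCc2cnc3ccc(-c4ccccc4)cn23)cc1` gives 9.9 ug/mL, and compound 3 `Cc1cc(-c2ccccc2)cn2c(CSCCc3ccccc3)cnc12` gives 31 ug/mL. Going by the values given here, compound 3 stands second highest of the three; its gap to compound 1 lies within the scatter, while the step of a 3.1-fold higher number from compound 2 to compound 3 (0.50 log units; beyond the scatter) is the one measured step and lies beyond the scatter.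

Compound 4 `Cc1cc(-c2cccc([N+](=O)[O-])c2)cn2c(CSCCc3ccccc3)cnc12` differs from compound 3 by nitro in place of hydrogen on an aromatic carbon, a nitro in place of hydrogen on an aromatic carbon, meta to a large group. Among the compounds with values here, no measured step concerns a nitro, or any change on this phenyl ring; the single step, methyl for hydrogen on the core, does not bear on it. Compound 1 carries a fluorine on the same ring, but it differs from compound 3 in more than one place and its number sits within the scatter of compound 3. On this basis no step beyond the scatter is expected in this assay, so compound 4 is estimated at 30 ug/mL, range 12 ug/mL to 70 ug/mL, a step of a 1.0-fold lower number from compound 3 to compound 4 (0.01 log units; within the scatter) that is expected to stay within the scatter.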

Compound 4, half-maximal cytotoxic concentration: 43 ug/mL
The estimate for compound 4 lay 1.4-fold (0.16 log units) below the measured number; measured number inside the range.
By their numbers in this assay, from the lowest: compound 2; then compounds 3, 1 and 4 (each within the scatter of the next).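

In this assay, going by these compounds alone, the one single-place comparison on this phenyl ring is the step of a 1.4-fold higher number from compound 3 to compound 4 (0.14 log units; within the scatter) and it is read as no detectable shift. At this place, on an aromatic carbon meta to a large group, the nitro adds 3 heavy atoms and 2 hydrogen-bond acceptors while the read-out stays within the scatter. The methyl on the core behaves differently, with the step of a 3.1-fold higher number from compound 2 to compound 3 (0.50 log units; beyond the scatter) lying beyond the scatter. No line of measured data on any property of the nitro bears on this result.

Open, as far as these compounds go, is whether an amine or a carboxylic acid at this same place would also stay within the scatter of compound 3. Equally open, from the compounds shown here alone, is whether the nitro would give a similar step on the core of compound 2, which lacks the methyl.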